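The source may hold more compounds than are shown below. What is called first, only, known or untested is meant among the compounds shown, and "the series" means these compounds.

Compound 1 `N#CC1=C(N)Oc2c(c3nc4ccccc4nc3c3ccccc23)C12C(=O)N(Cc1cnnn1-c1cccc(Cl)c1)c1ccccc12` gives 35200 nM in an ADME assay on L02 cells (Homo sapiens) for antiproliferative activity, read by MTT assay, with a stated time of 48 h; on this read-out lower numbers stand for stronger inhibition and higher numbers for weaker inhibition.
Compound 2 `COc1ccccc1-n1nncc1CN1C(=O)C2(C(C#N)=C(N)Oc3c2c2nc4ccccc4nc2c2ccccc32)c2ccccc21` reaches only the limit of this assay, > 50000 nM, so no number is known for it.

Compound 2 thus stands at the limit of > 50000 nM in this assay, at which 1 of the 2 values shown sits, and its true value could lie anywhere beyond that point. Compound 3 `CCOc1ccc(-n2nncc2CN2C(=O)C3(C(C#N)=C(N)Oc4c3c3nc5ccccc5nc3c3ccccc43)c3ccccc32)cc1` differs from compound 2 in one place: 4-ethoxyphenyl in place of 2-methoxyphenyl on an aromatic nitrogen. Among the measured compounds shown here, one measured step bears on this kind of change, a swap of the group on the same aromatic nitrogen: an at least 1.4-fold higher number from compound 1 to compound 2 (0.15 log units; that floor lies within the scatter). That step was small and ended at the limit, so it gives little guidance on direction or size. Compound 2 already sits at the limit. The step expected here, a step that the limit leaves unreadable from compound 2 to compound 3, is none beyond the scatter. Compound 3 is estimated at 55000 nM, with a range from 30000 nM to 100000 nM, and most likely this assay will again report only its limit.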

Compound 3, half-maximal inhibitory concentration: > 50000 nM
Compound 3: a limit, no number; the forecaster's own chance of this, stated with the estimate: 70%; the middle value does not contradict the limit.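

With 4-ethoxyphenyl on the aromatic nitrogen, compound 3 ends at a limit in this assay, as compound 2 does, so two different alkoxy-bearing phenyl groups now share that outcome: the limit of > 50000 nM in this assay, at which 2 of the 3 values shown sit. The step from compound 2 to compound 3 cannot be read, as both values are limits, so the change from 2-methoxyphenyl to 4-ethoxyphenyl has no measurable size here. Replacing 3-chlorophenyl with 4-ethoxyphenyl gives an at least 1.4-fold higher number from compound 1 to compound 3 (0.15 log units; that floor lies within the scatter), so no real difference from compound 1 is established.

Still open, going by these compounds, is whether any group at this position would give a value clearly lower than that of compound 1. A phenyl ring carrying an amine or a carboxylic acid, or a longer alkoxy chain, could answer this only if its value fell inside the measurable range.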